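The source may hold more compounds than are shown below. What is called first, only, known or untested is meant among the compounds shown, and "the series" means these compounds.

Measured compounds:
compound 1 `C[C@@H](NC1CCN(CCCc2c[nH]c3ccc(-n4cnnc4)cc23)CC1)c1ccccc1` 90%
compound 2 `CN(Cc1ccsc1)C1CCN(CCCc2c[nH]c3ccc(-n4cnnc4)cc23)CC1` 93%
compound 3 `O[C@@H]1Cc2ccccc2[C@H]1NC1CCN(CCCc2c[nH]c3ccc(-n4cnnc4)cc23)CC1` 75%

In a functional assay on CHO cells for activation of 5-hydroxytryptamine receptor 1D (Homo sapiens), read by GTPgammaS binding (a higher number here means a larger maximal response, a lower number a smaller maximal response), compound 3 stands lowest of the three, separated from compound 1 by a number 15 percentage points lower from compound 1 to compound 3 (beyond the scatter) and from compound 2 by a number 18 percentage points lower from compound 2 to compound 3 (beyond the scatter), both beyond the scatter. Compound 4 `c1ccc2c(c1)CCC2NCC1CCN(CCCc2c[nH]c3ccc(-n4cnnc4)cc23)CC1` differs from compound 3 by ((2,3-dihydro-1H-inden-1-yl)amino)methyl in place of (2-hydroxy-2,3-dihydro-1H-inden-1-yl)amino on a saturated ring carbon. Going by the values given here, no measured step covers this change directly; the two steps that lead into compound 3 show that the 2-hydroxy-2,3-dihydro-1H-inden-1-yl group sits somewhat below the other amines, so its replacement is expected to recover part of that loss, with the new linker adding uncertainty. For compound 4 the expected step is a number 10 percentage points higher from compound 3 to compound 4 (within the scatter), giving an estimate of 85% with a range from 65% to 100%.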

Compound 4, largest response reached (reported as efficacy), in percent of the reference or control that the assay uses: 78%
Estimate against measurement, compound 4: 7 percentage points above, within the range that was stated.
By their numbers in this assay, from the lowest: compounds 3 and 4 (each within the scatter of the next); then compounds 1 and 2 (each within the scatter of the next).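

In this assay the result is a number 3 percentage points higher from compound 3 to compound 4 (within the scatter), so ((2,3-dihydro-1H-inden-1-yl)amino)methyl at this ring carbon, which lacks the hydroxyl, does not separate from the (2-hydroxy-2,3-dihydro-1H-inden-1-yl)amino group. The other steps are a number 15 percentage points lower from compound 2 to compound 4 (beyond the scatter) and a number 12 percentage points lower from compound 1 to compound 4 (beyond the scatter), so among these compounds, both of those carrying the dihydroindenyl ring sit under the two without it, and the hydroxyl alone does not account for that gap. Nothing available explains this. Because this change removes the hydroxyl and adds a methyl link together, their separate contributions remain unresolved. Going by these compounds, it also remains open how the unsubstituted (2,3-dihydro-1H-inden-1-yl)amino group, attached directly to the ring carbon, or a longer ethyl link would behave.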